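From chloro to methyl: what to expect of compound 4

The source may hold more compounds than are shown below. What is called first, only, known or untested is meant among the compounds shown, and "the series" means these compounds.

Values so far in a functional assay on K562 cells (Homo sapiens) for inhibition, read by trypan blue exclusion, with a stated time of 24 h (on this read-out lower numbers stand for stronger inhibition and higher numbers for weaker inhibition), are these
compound 1 `NC(=O)c1cc(Cl)ccc1NC(=O)COc1ccccc1` gives 1300 nM
compound 2 `Cc1ccccc1OCC(=O)Nc1ccc(Cl)cc1C(N)=O` gives 1610 nM
compound 3 `Cc1ccc(OCC(=O)Nc2ccc(I)cc2C(N)=O)cc1` gives 10000 nM
compound 4 `Cc1ccc(NC(=O)COc2ccccc2)c(C(N)=O)c1` has no value yet

Compound 1 at 1300 nM stands level with compound 2 within the scatter, while compound 3 at 10000 nM gives a clearly higher number than compound 1.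

Compound 4 keeps the core of compound 1 and carries one change, methyl in place of chloro on an aromatic carbon describes it in full.

Within the data shown here, only one measured step bears on this change. The step of a 1.2-fold higher number from compound 1 to compound 2 (0.09 log units; within the scatter) also brings in a methyl, but in place of hydrogen, so it is indirect evidence. Among the measured compounds shown here, no measured step replaces chloro, which leaves the expectation loose. The expected step is a 1.7-fold higher number from compound 1 to compound 4 (0.23 log units; within the scatter) in this assay and it is estimated to be small, leaning towards a higher number, with no clear move beyond the scatter foreseen. In this assay the expected value for compound 4 is 2200 nM with an estimated range of 800 nM to 6500 nM.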

Compound 4, half-maximal inhibitory concentration: 4700 nM
Beside the measured number, compound 4's estimate is 2.1-fold (0.33 log units) below it, within the range that was stated.
By their numbers in this assay, from the lowest: compounds 1 and 2 (each within the scatter of the next); then compound 4; then compound 3.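

In this assay, replacing chloro with methyl on this aromatic carbon, para to a large group, gives a 3.6-fold higher number from compound 1 to compound 4 (0.56 log units; beyond the scatter), so the two groups are not interchangeable here, even though each counts as one heavy atom with no hydrogen-bond donors or acceptors. Among these compounds, the only earlier step, a 1.2-fold higher number from compound 1 to compound 2 (0.09 log units; within the scatter), brought in a methyl in place of hydrogen, and this new step is the first to show that a single-atom swap on the core of compound 1 can move the number beyond the scatter. Nothing available explains why methyl and chloro differ at this position.

Compound 3 carries iodo at this position but also differs from compound 1 by a methyl, so it does not show the effect of iodo alone. On these data alone, it remains open how a bromo, a methoxy or an amine at this position would compare with chloro on the otherwise unchanged core.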